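The compounds below may be only part of what the source reports. "The series", "measured", "known", "first", "only" and "open" are said of these compounds alone.

Measured compounds:
compound 1 `C#CCN(CCCOc1ccc2ccc(=O)oc2c1)Cc1ccc(C)cc1`, 116000 nM
compound 2 `C#CCN(CCCCOc1ccc2ccc(=O)oc2c1)Cc1cccc(F)c1`, 69200 nM
compound 3 `C#CCN(CCCCOc1ccc2ccc(=O)oc2c1)Cc1ccc(C)cc1`, 94500 nM

In an ADME assay on isolated protein for inhibition of Amine oxidase [flavin-containing] A (Homo sapiens), read by fluorescence and Amplex Red, with stated times of 15 min and 20 min (a higher number here means a weaker inhibitor, a lower number a stronger inhibitor), compound 1 gives 116000 nM, the highest of the three numbers, though its gaps to compound 3 and to compound 2 both lie within the scatter, so no ranking among the three can be drawn from them. Compound 4 `C#CCN(CCCOc1ccc2ccc(=O)oc2c1)Cc1cccc(F)c1` has not yet been measured. It differs from compound 1 in one place: 3-fluorophenyl in place of 4-methylphenyl on a saturated chain carbon bound to an amine nitrogen.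

Among the compounds with values here, only one measured step bears on this exchange. It is the same swap of aryl groups run the other way, on the pair whose chain to the core is one carbon longer: a 1.4-fold higher number from compound 2 to compound 3 (0.14 log units; within the scatter). That step is within the scatter, so the exchange of 3-fluorophenyl and 4-methylphenyl left the number essentially unchanged there. Compound 4 is therefore expected to show no step beyond the scatter from compound 1 in this assay, with at most a slight lean toward a lower number, as a 1.4-fold lower number from compound 1 to compound 4 (0.14 log units; within the scatter). For compound 4 the estimate is 85000 nM, with a range from 40000 nM to 180000 nM.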

Compound 4, half-maximal inhibitory concentration: 29300 nM
For compound 4 the middle estimate is 2.9-fold (0.46 log units) above the measured one; measured number outside the range, below it.
By their numbers in this assay, from the lowest: compound 4; then compounds 2, 3 and 1 (each within the scatter of the next).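

In this assay, within the data shown here, the exchange at this place, on a saturated chain carbon bound to an amine nitrogen, is not silent on every core, as the earlier compounds alone had suggested: a 4.0-fold lower number from compound 1 to compound 4 (0.60 log units; beyond the scatter). The size of the exchange therefore differs between the core with the shorter chain and the core with the chain one carbon longer: the same change on two cores in this assay, a 1.4-fold higher number (0.14 log units; within the scatter) from compound 2 to compound 3 and a 4.0-fold higher number (0.60 log units; beyond the scatter) from compound 4 to compound 1, 2.9-fold (0.46 log units) apart, beyond the scatter of two such steps. With only these two pairs to compare, the effect of going from 4-methylphenyl to 3-fluorophenyl is tied to its core and cannot be read as a general rule for this position.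

The compounds shown leave open how much of the step goes with losing the methyl and how much with gaining the fluorine, which an unsubstituted phenyl, a 4-fluorophenyl or a 3-methylphenyl at this place would help to separate. From the compounds shown here alone, it also remains open how the same exchange behaves on a still longer chain.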